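From fluoro to bromo: estimating compound 4

The source may hold more compounds than are shown below. What is called first, only, known or untested is meant among the compounds shown, and "the series" means these compounds.

Of the compounds shown here, three have been measured so far in a physicochemical assay for lipophilicity; on this read-out higher numbers stand for higher lipophilicity and lower numbers for lower lipophilicity. Compound 1 `COc1c(OC)c(OC(C)=O)c2ccccc2c1OC(C)=O` gives 2.39, compound 3 `COc1c(OC)c(OC(C)=O)c2cc(F)ccc2c1OC(C)=O` gives 2.75, and compound 2 `CCCC(=O)Oc1c(OC)c(OC)c(OC(=O)CCC)c2ccccc12` gives 4.64. Compound 3 therefore stands second highest of the three, above compound 1 and well below compound 2.

Compound 4 `COc1c(OC)c(OC(C)=O)c2cc(Br)ccc2c1OC(C)=O` has not yet been measured. Its difference from compound 3 is bromo in place of fluoro on an aromatic carbon, meta to a fused ring and para to a fused ring.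

Among the measured compounds shown here, only one measured step bears on this carbon: a number 0.36 log units higher from compound 1 to compound 3 (beyond the scatter), a modest rise with fluoro in place of hydrogen. For the measured compounds named here, no bromo compound has been measured, so this single step is the only guide. An upward step beyond the scatter in this assay is expected, somewhat larger than that precedent. The expected change is a number 0.50 log units higher from compound 3 to compound 4 (beyond the scatter). For compound 4 the estimated value is 3.25, with an expected range of 2.95 to 3.6.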

Compound 4, partition coefficient: 3.39
The estimate for compound 4 lay 0.14 log units below the measured number, and the stated range covers the measured number.
By their numbers in this assay, from the lowest: compound 1; then compound 3; then compound 4; then compound 2.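

In this assay this aromatic carbon, meta to a fused ring and para to a fused ring, now carries hydrogen, fluoro or bromo on an otherwise unchanged core, and the number rises in that order. Bromo in place of fluoro gives a number 0.64 log units higher from compound 3 to compound 4 (beyond the scatter) and bromo in place of hydrogen gives a number 1.00 log units higher from compound 1 to compound 4 (beyond the scatter) while fluoro in place of hydrogen gave the smaller a number 0.36 log units higher from compound 1 to compound 3 (beyond the scatter) so the choice of halogen at this carbon shifts the read-out by more than the scatter. No measured evidence accounts for the size of these steps.

Open, from the compounds shown here alone, is whether chloro, iodo, an amine or a carboxylic acid at this carbon would follow the same order. Also open, going by these compounds, is whether bromo in place of hydrogen would give a similar step with the longer ester chains of compound 2.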